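A Butoxy Group in Place of Hydrogen on Compound 2

The source may report more compounds than this note shows. Statements on the series, on what has been measured and on what is new or still open speak of the compounds shown alone.

Compound 2 `O=C(Nc1nn[nH]n1)c1ccccn1` was tested in a functional assay on the whole organism for inhibition, with Rattus norvegicus as the target, at a dose of 3 mg/kg by the oral route (a lower number here means a weaker effect, a higher number a stronger effect of the compound at the dose given), and gave 29%. Among the compounds with values here, the only other measured compound, compound 1 `O=C(Nc1nn[nH]n1)c1cccc(Br)n1`, gave 38% in this assay; the step of a number 9 percentage points lower from compound 1 to compound 2 (within the scatter) is therefore small, as hydrogen in place of bromo on an aromatic carbon changed little. Compound 3 `CCCCOc1cccc(C(=O)Nc2nn[nH]n2)n1` differs from compound 2 by butoxy in place of hydrogen on an aromatic carbon. Within the data shown here, no measured step involves a butoxy group, so only the small bromo-to-hydrogen step offers guidance, and no change beyond the scatter is expected. Compound 3 is estimated to give 35%, between 10% and 65%, a step of a number 6 percentage points higher from compound 2 to compound 3 (within the scatter).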

Compound 3, a percentage reported as inhibition, in the whole organism at one dose (the size of the read-out at that dose, not a potency): 18%
The estimate for compound 3 lay 17 percentage points above the measured number, and the stated range covers the measured number.
By their numbers in this assay, from the lowest: compound 3; then compounds 2 and 1 (each within the scatter of the next).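

In this assay, within the data shown here, butoxy on the aromatic carbon next to the ring nitrogen gives the first step at this position that goes beyond the scatter (a number 11 percentage points lower from compound 2 to compound 3 (beyond the scatter)). Butoxy in place of bromo gives a modest step as well (a number 20 percentage points lower from compound 1 to compound 3 (beyond the scatter)). So this position does not treat all groups alike, yet no measurement at hand explains why.

On these data alone, whether the lower number follows the oxygen or the length of the chain stays open. Methoxy, a longer chain or an amine at this position could help to separate these.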